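Removing a methyl from the phenolic oxygen of compound 1

The compounds below may be only part of what the source reports. "The series", "measured", "known", "first", "only" and "open" are said of these compounds alone.

Compounds measured so far:
compound 1, `COc1cc(/C=N/Nc2nc3ccccc3s2)cc(OC)c1O`: 39%
compound 2, `COc1cc(/C=N/Nc2nc3ccccc3s2)cc(OC)c1OC`: 4%

Two compounds share the core of compound 1 and differ only on one oxygen on an aromatic ring. In a functional assay on cells (Mus musculus) for cytotoxicity, read by MTT assay, with a stated time of 24 h, tested at 1 uM (a lower number here means a weaker effect, a higher number a stronger effect of the compound at the concentration tested), compound 1 gives 39%, the higher of the two numbers. Compound 2 carries methyl in place of hydrogen on that oxygen and gives 4%; the step of a number 35 percentage points lower from compound 1 to compound 2 (beyond the scatter) lies beyond the scatter.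

Compound 3, `COc1cc(/C=N/Nc2nc3ccccc3s2)cc(O)c1O`, has not been measured. It differs from compound 1 by hydrogen in place of methyl on an oxygen on an aromatic ring, so that the methoxy becomes a hydroxy. Among the measured compounds shown here, the only step at hand runs the other way: adding a methyl on such an oxygen, from compound 1 to compound 2, cost a large amount of activity. Taking a methyl away from compound 1 is therefore expected to leave the number at least where it is, or raise it. Compound 3 is thus estimated at 52%, within 32% to 75%, an expected step of a number 13 percentage points higher from compound 1 to compound 3 (beyond the scatter), because the step of a number 35 percentage points lower from compound 1 to compound 2 (beyond the scatter) pointed downward on adding methyl.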

Compound 3, a percentage reported as activity, at one concentration (the size of the read-out at that concentration, not a potency): 38%
Compound 3: the middle estimate sits 14 percentage points above what was measured, within the range that was stated.
By their numbers in this assay, from the lowest: compound 2; then compounds 3 and 1 (each within the scatter of the next).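

In this assay, the exchange of methoxy for hydroxy on this oxygen gives a number 1 percentage points lower from compound 1 to compound 3 (within the scatter), so the number does not respond to losing this methyl. The earlier step, a number 35 percentage points lower from compound 1 to compound 2 (beyond the scatter), was made on a different oxygen, the one that carries hydrogen in compound 1, so these two steps show that swapping methyl and hydrogen on an oxygen of this aromatic ring does not have one outcome at every oxygen: it is large at the hydroxy oxygen of compound 1 and within the scatter at the methoxy oxygen changed in compound 3. Nothing available explains why the two oxygens differ in this way.

The compounds shown leave open whether this methoxy position would also tolerate a group larger than methyl, such as an ethyl or a longer chain on the oxygen, or a different group in place of the oxygen, such as an amine or a carboxylic acid. They also leave open whether the hydroxy oxygen of compound 1 is lost to any group placed on it, or only to methyl, since a single step at one concentration cannot settle that.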